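The source may report more compounds than this note shows. Statements on the series, on what has been measured and on what is new or still open speak of the compounds shown alone.

Compounds measured in a functional assay on PANC-1 cells (Homo sapiens) for inhibition, read by MTT assay, with a stated time of 24 h, tested at 10 uM; on this read-out higher numbers stand for more inhibition at the one concentration tested (going by the name of the read-out) and lower numbers for less inhibition:

compound 1, `CC(C)=CCC1Cc2c(OCc3ccccc3)cc(=O)n(CCCO)c2CC1(C)C`: 11.1%
compound 2, `CC(C)=CCC/C(C)=C/COc1cc(=O)n(CCCO)c2c1CC(CC=C(C)C)C(C)(C)C2`: 18.4%
compound 3, `COc1ccc(C(=O)NCCCOc2cc(=O)n(CCCO)c3c2CC(CC=C(C)C)C(C)(C)C3)cc1`: 2.5%

On these numbers compound 3 stands lowest of the three; its nearest neighbour is compound 1, within the scatter, and compound 2 lies beyond the scatter above it. Compound 4, `CC(C)=CCC1Cc2c(OCCCOc3ccc([N+](=O)[O-])cc3)cc(=O)n(CCCO)c2CC1(C)C`, differs from compound 3 by 4-nitrophenoxy in place of ((4-methoxyphenyl)carbonyl)amino on a saturated chain carbon, three bonds along the chain from an oxygen on an aromatic ring. Going by the values given here, the one measured step, a number 7.3 percentage points higher from compound 1 to compound 2 (within the scatter), was within the scatter and concerns another place on the core, so no measured step bears directly on the present change. Compound 4 is therefore expected to stay near compound 3, with no step beyond the scatter: the estimate for compound 4 is 8%, between -6% and 24%, a change of a number 5.5 percentage points higher from compound 3 to compound 4 (within the scatter).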

Compound 4, a percentage reported as inhibition, at one concentration (the size of the read-out at that concentration, not a potency): 0%
For compound 4 the middle estimate is 8 percentage points above the measured one; the measured number falls inside the stated range.
By their numbers in this assay, from the lowest: compounds 4, 3, 1 and 2 (each within the scatter of the next, the first and the last beyond it).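

In this assay, 4-nitrophenoxy in place of ((4-methoxyphenyl)carbonyl)amino on a saturated chain carbon does not separate the two compounds (a number 2.5 percentage points lower from compound 3 to compound 4 (within the scatter)). On the carbon bound to the oxygen, 2-(4-nitrophenoxy)ethyl gives modest steps beyond the scatter, both in place of phenyl (a number 11.1 percentage points lower from compound 1 to compound 4 (beyond the scatter)) and in place of 2,6-dimethylhepta-1,5-dien-1-yl (a number 18.4 percentage points lower from compound 2 to compound 4 (beyond the scatter)). On these data alone, whether an amine or a carboxylic acid at the end of this chain would raise the number remains open. Nothing available explains these differences.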